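A few compounds are considered here, and "the series" means these few. Any claim that something is new, unique, unknown or untested is made for them only; others in the source may bear on it.

In a functional assay on OVCAR-5 cells (Homo sapiens) for inhibition, read by CCK-8 assay, with a stated time of 72 h, tested at 10 uM (on this read-out higher numbers stand for more inhibition of growth at the one concentration tested and lower numbers for less inhibition of growth), compound 2 `CN(C)C(=O)c1cc2cnc(Nc3ccc(NC(=O)C4(C(=O)Nc5ccc(Br)cc5)CC4)cc3)nc2n1C1CCCC1` gives 87.8% and compound 1 `CN(C)C(=O)c1cc2cnc(Nc3ccc(NC(=O)C4(C(=O)Nc5cccc(F)c5)CC4)cc3)nc2n1C1CCCC1` gives 85.6%, two values within the scatter of each other, so compound 2 stands level with compound 1. The unmeasured compound 3 `Cc1ccc(NC(=O)C2(C(=O)Nc3ccc(Nc4ncc5cc(C(=O)N(C)C)n(C6CCCC6)c5n4)cc3)CC2)cc1` differs from compound 2 in a single substituent: methyl in place of bromo on an aromatic carbon, para to a large group. Going by the values given here, only one measured step bears on this change, 4-bromophenyl in place of 3-fluorophenyl on an amide-type nitrogen. It amounts to a number 2.2 percentage points higher from compound 1 to compound 2 (within the scatter) and is a small step within the scatter. On this single step, no change beyond the scatter is expected in this assay and no direction can be favoured. The expected step is a number 2.8 percentage points lower from compound 2 to compound 3 (within the scatter) and would lie within the scatter. Compound 3 is estimated at 85% with an expected range from 74% to 94% in this read-out.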

Compound 3, percent growth inhibition at one concentration: 80.6%
Estimate against measurement, compound 3: 4.4 percentage points above; low and high end bracket the measured number.
By their numbers in this assay, from the lowest: compounds 3, 1 and 2 (each within the scatter of the next).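

Replacing bromo with methyl on this aromatic carbon, para to a large group, gives a number 7.2 percentage points lower from compound 2 to compound 3 (within the scatter) in this assay. Moving from 3-fluorophenyl to 4-methylphenyl on the amide-type nitrogen gives a number 5 percentage points lower from compound 1 to compound 3 (within the scatter), so these three compounds stand level and a halogen on this ring is not required for growth inhibition in this range at the one concentration tested. No measurement on these compounds offers an explanation for this result.

Still open, on these data alone, is whether an amine, a carboxylic acid or a longer chain such as butyl in place of the methyl would keep growth inhibition at this level. With a single concentration, it is also unknown whether these three level compounds would separate at lower concentrations.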